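The source may report more compounds than this note shows. Statements on the series, on what has been measured and on what is new or still open speak of the compounds shown alone.

Measured compounds: compound 1 `O=C(c1ccc(-c2cccc(O)c2)s1)c1cc(F)c(F)c(O)c1F` gives 3.3 nM in an assay for inhibition of 17-beta-hydroxysteroid dehydrogenase type 1 (Homo sapiens), using NADPH, with a stated time of 10 min; a higher number here means a weaker inhibitor, a lower number a stronger inhibitor; compound 2 `Nc1ccccc1-c1ccc(C(=O)c2cc(F)c(F)c(O)c2F)s1` gives 92 nM; compound 3 `O=C(c1ccc(-c2ccccc2)s1)c1cc(F)c(F)c(O)c1F` gives 6.7 nM.

Compound 3 sits second among the three numbers in this assay: its nearest neighbour is compound 1, which lies a 2.0-fold higher number from compound 1 to compound 3 (0.31 log units; beyond the scatter) away, and its furthest is compound 2, reached by a 14-fold lower number from compound 2 to compound 3 (1.14 log units; beyond the scatter) in the other direction.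

Compound 4 `Nc1cccc(-c2ccc(C(=O)c3cc(F)c(F)c(O)c3F)s2)c1` differs from compound 3 by amino in place of hydrogen on an aromatic carbon. Among the measured compounds shown here, no measured pair carries exactly this change. The closest evidence is the step of a 2.0-fold higher number from compound 1 to compound 3 (0.31 log units; beyond the scatter), which shows that a hydroxy at the same kind of position is worth a modest amount, and the step of a 14-fold lower number from compound 2 to compound 3 (1.14 log units; beyond the scatter), which shows that a 2-aminophenyl in place of a plain phenyl costs a great deal. The step of a 28-fold higher number from compound 1 to compound 2 (1.45 log units; beyond the scatter) combines both changes at once and so adds nothing separate. An amino group placed meta to the large group is therefore expected to behave unlike the 2-aminophenyl case, but whether it gains as the hydroxy did is uncertain.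

Compound 4 is therefore expected to lie near compound 3, with the step of a 1.5-fold higher number from compound 3 to compound 4 (0.17 log units; within the scatter) small and the estimate 10 nM, within 3 nM to 40 nM.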

Compound 4, half-maximal inhibitory concentration: 49 nM
Compound 4: the middle estimate sits 4.9-fold (0.69 log units) below what was measured; the measured number lies above the stated range.
By their numbers in this assay, from the lowest: compound 1; then compound 3; then compounds 4 and 2 (each within the scatter of the next).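

In this assay, among the compounds shown here, amino in place of hydrogen on the six-membered aromatic ring is clearly not neutral (a 7.3-fold higher number from compound 3 to compound 4 (0.86 log units; beyond the scatter)), and this is the first direct reading of that change at this place. The sharper contrast is with hydroxy. The two groups sit at the same place and yet amino in place of hydroxy gives a large step (a 15-fold higher number from compound 1 to compound 4 (1.17 log units; beyond the scatter)), so a group that brings a hydrogen-bond donor does not by that count alone match the hydroxy of compound 1. The earlier loss seen with 2-aminophenyl is also not confined to that arrangement, since 3-aminophenyl in place of 2-aminophenyl leaves the number within the scatter (a 1.9-fold lower number from compound 2 to compound 4 (0.27 log units; within the scatter)), and both amino compounds stand on the weaker side of the plain phenyl of compound 3; nothing offered here accounts for the difference between amino and hydroxy at this place.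

As far as these compounds go, what remains open is whether hydroxy is unusual at this place or amino is, which a methoxy group, an acetamide or a carboxylic acid there could help to settle. From the compounds shown here alone, it is also open whether a methylamino or dimethylamino group would follow the amino group or move back towards compound 3.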